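Series notes: replacing the aryl group of compound 2

The compounds below may be only part of what the source reports. "The series", "measured", "known", "first", "only" and "open" are said of these compounds alone.

In an ADME assay on L6 cells (Rattus norvegicus) for cytotoxicity, read by resazurin assay (on this read-out lower numbers stand for stronger inhibition and higher numbers for weaker inhibition), compound 2 `COc1cc(OC)cc(-c2nc3ccc(-c4nc5cc(C(=N)N)ccc5[nH]4)cc3[nH]2)c1` gives 25.5 ug/mL. Compound 1 `N=C(N)c1ccc2[nH]c(-c3ccc4nc(-c5ccccc5F)[nH]c4c3)nc2c1` gives 26.8 ug/mL, and compound 3 `COc1ccc(Oc2ccc(-c3nc4ccc(-c5nc6cc(C(=N)N)ccc6[nH]5)cc4[nH]3)cc2)cc1OC` gives 29.4 ug/mL. These three numbers lie within the scatter of one another, so compound 2 stands level with the other two.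

The step under consideration leads to compound 4 `N=C(N)c1ccc2[nH]c(-c3ccc4nc(-c5ccc6ccccc6c5)[nH]c4c3)nc2c1`: naphthalen-2-yl in place of 3,5-dimethoxyphenyl on an aromatic carbon. Among the compounds with values here, the one measured step that bears on it changes the group at the same place on the shared core: a 1.1-fold lower number from compound 1 to compound 2 (0.02 log units; within the scatter), which is within the scatter. Compound 3 carries a further group there, and its number is also level with the others. Within the data shown here, no measured compound carries naphthalen-2-yl, so the support is limited, and the range is kept wide. No change beyond the scatter is expected in this assay, in either direction. The estimated step is a 1.1-fold lower number from compound 2 to compound 4 (0.03 log units; within the scatter). Compound 4 is estimated at 24 ug/mL, with an expected range of 10 ug/mL to 50 ug/mL.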

Compound 4, half-maximal inhibitory concentration: 34.7 ug/mL
Compound 4: the middle estimate sits 1.4-fold (0.16 log units) below what was measured; the measured number falls inside the stated range.
By their numbers in this assay, from the lowest: compounds 2, 1, 3 and 4 (each within the scatter of the next).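

With naphthalen-2-yl on the aromatic carbon between two ring nitrogen atoms, this assay gives a 1.4-fold higher number from compound 2 to compound 4 (0.13 log units; within the scatter) and a 1.3-fold higher number from compound 1 to compound 4 (0.11 log units; within the scatter) as its two new steps. The earlier compounds shown here did not show that two six-membered aromatic rings of carbon only can stand at this place without a step beyond the scatter, and the exchange for 3,5-dimethoxyphenyl also removes both oxygen atoms without such a step. Nothing at hand accounts for this level picture.

On these data alone, whether an amine, a carboxylic acid or a longer chain on the aryl group at this place would give a step beyond the scatter stays open. The compounds shown also leave open whether any of these groups would behave in the same way in a read-out other than this cytotoxicity measurement.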